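The compounds below may be only part of what the source reports. "The series", "measured", "known", "first", "only" and "open" are said of these compounds alone.

Measured compounds:
- compound 2 `S=C(N/N=C/c1ccc(Cl)cc1)N1CCNCC1` — 69000 nM
- compound 1 `COc1ccc(/C=N/NC(=S)N2CCNCC2)cc1` — "not determined" (no result reported)

The study concerns a small set of thiosemicarbazones built on a shared core. Going by the values given here, in a functional assay on HL-60 cells (Homo sapiens) for antiproliferative activity, with a stated time of 48 h (a lower number here means a stronger inhibitor, a higher number a weaker inhibitor), compound 2 gives 69000 nM, and this is the only number reported in the whole set; compound 1, carrying a methoxy group instead, is recorded in this assay as "not determined" (no result reported), so it contributes no number to compare with. Compound 2 therefore stands alone, and it is a weak inhibitor on the scale of this read-out.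

The step now followed leads from compound 2 to compound 3 `Oc1ccc(/C=N/NC(=S)N2CCNCC2)cc1`. The change is hydroxy in place of chloro on an aromatic carbon. Among the compounds with values here, no pair of measured compounds differing in one place is available here, so nothing within the data tells how large such an exchange tends to be. Within the data shown here, with a single weak starting point and no comparable step, the expectation is that compound 3 moves little beyond the usual scatter, with perhaps a slight drift toward weaker inhibition, expected as a 1.2-fold higher number from compound 2 to compound 3 (0.09 log units; within the scatter). Compound 3 is accordingly estimated at 85000 nM, within a range of 20000 nM to 350000 nM.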

Compound 3, half-maximal inhibitory concentration: 50000 nM
For compound 3 the middle estimate is 1.7-fold (0.23 log units) above the measured one; measured number inside the range.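

Going by these compounds alone, the exchange gives the first readable step at this position, on an aromatic carbon of a six-membered aromatic ring of carbon only, para to a large group. In this assay hydroxy in place of chloro amounts to a 1.4-fold lower number from compound 2 to compound 3 (0.14 log units; within the scatter) and so does not separate the two compounds, even though the entering group brings a hydrogen-bond donor and a hydrogen-bond acceptor that the chloro lacks, so this one exchange gives no sign that the read-out responds to the group at this position. Nothing at hand offers a measurement that would help to interpret this step.

On these data alone, whether the position stays as unresponsive with an amine, a carboxylic acid or a longer chain in the same place remains open, and compound 1, with its methoxy group there, offers no number to settle it. One step between two compounds also leaves open whether any change elsewhere on the shared core, such as on the piperazine-free end of the series, would move the number beyond the scatter.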